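Chloro in place of hydrogen, repeated on a second core

The compounds below may be only part of what the source reports. "The series", "measured", "known", "first", "only" and "open" are said of these compounds alone.

Compound 1 `O=C(CCCCC(S)CCS)Nc1ccccc1` and compound 2 `O=C(CCCCC(S)CCS)Nc1ccc(Cl)cc1` share one core. In a functional assay on KB cells (Homo sapiens) for inhibition, read by MTT assay, with a stated time of 24 h, tested at 10 ug/mL (on this read-out lower numbers stand for less inhibition of growth and higher numbers for more inhibition of growth at the one concentration tested), compound 1 gives 8.62%, and compound 2 gives 18.2%. The difference between them is chloro in place of hydrogen on an aromatic carbon, and the step it made is a number 9.6 percentage points higher from compound 1 to compound 2 (within the scatter).

Compound 3 `O=C(CCCCC(CCSC(=O)c1ccccc1)SC(=O)c1ccccc1)Nc1ccccc1` carries a second core; how it differs from compound 1 is not broken down here. In this assay compound 3 gives 2.67%, which sits close to the number for compound 1 and is a lower number than that of compound 2.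

Compound 4 `O=C(CCCCC(CCSC(=O)c1ccccc1)SC(=O)c1ccccc1)Nc1ccccc1Cl` is not yet measured. It differs from compound 3 by chloro in place of hydrogen on an aromatic carbon. For the measured compounds named here, this is the same kind of change as the one from compound 1 to compound 2, but not the same: in the first case the chloro sits para to a large group, in the second it sits ortho to a large group. Only these two occurrences of the change appear among the compounds shown, so nothing more general can be drawn from them.

Going by the values given here, for compound 4 in this assay the expected step is a number 6.3 percentage points higher from compound 3 to compound 4 (within the scatter), which rests on the one earlier step of this kind, a number 9.6 percentage points higher from compound 1 to compound 2 (within the scatter), and on the starting number of compound 3, 2.67%. The estimate for compound 4 is therefore 9%, with a range from 0% to 22%.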

Compound 4, percent growth inhibition at one concentration: 2.53%
Compound 4: the middle estimate sits 6.5 percentage points above what was measured; the range from low to high includes it.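

In this assay, chloro in place of hydrogen on the aromatic ring of the second core gives a number 0.1 percentage points lower from compound 3 to compound 4 (within the scatter), so phenylcarbamoyl to (2-chlorophenyl)carbamoyl leaves no readable change on this core. Set beside the earlier step on the first core, the new step cannot be told apart from it: the same change on two cores in this assay, a number 9.6 percentage points higher (within the scatter) from compound 1 to compound 2 and a number 0.1 percentage points lower (within the scatter) from compound 3 to compound 4, 9.7 percentage points apart, within the scatter of two such steps

For the compounds shown here, this is consistent with the change reading alike on both cores, but it does not show that any effect carries over, since neither step lies beyond the scatter and the series offers only two occurrences of the change, each read at a single concentration; the chloro also sits ortho to a large group in compound 4 and at a different place in compound 2, so core and place cannot be separated here.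

Still open, on these data alone, is whether chloro at the same place on both cores would give matching steps, and whether a step beyond the scatter can be reached on either core at all. Also open, as far as these compounds go, is how other groups on the same aromatic ring, such as a methoxy group, a carboxylic acid or an amine, or a longer chain between the amide and the sulfur-bearing carbons, would read on these two cores.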